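Working notes: 4-fluorophenyl in place of 2-chloro-6-fluorophenyl

The source may hold more compounds than are shown below. What is called first, only, known or untested is meant among the compounds shown, and "the series" means these compounds.

Values so far in a functional assay on HeLa cells (Homo sapiens) for cytotoxicity, read by MTT assay, with a stated time of 48 h (on this read-out higher numbers stand for an effect only at larger amounts of compound and lower numbers for an effect already at smaller amounts), are as follows:
- compound 1 `CSc1ccc(/C=N/n2c(Cc3ccc(S(C)(=O)=O)cc3)n[nH]c2=S)cc1` gives 50000 nM as a measured number
- compound 2 `CS(=O)(=O)c1ccc(Cc2n[nH]c(=S)n2/N=C/c2cccnc2)cc1` gives > 100000 nM as a limit of the assay, not a number
- compound 3 `CS(=O)(=O)c1ccc(Cc2n[nH]c(=S)n2/N=C/c2c(F)cccc2Cl)cc1` gives 25000 nM as a measured number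
- compound 4 `CS(=O)(=O)c1ccc(Cc2n[nH]c(=S)n2/N=C/c2ccc(F)cc2)cc1` has no value yet

Among the compounds with values here, compound 3 holds one of only two real numbers, and a 2.0-fold lower number from compound 1 to compound 3 (0.30 log units; within the scatter) gives no order between the pair. Against the remaining compound, the step is an at least 4.0-fold lower number from compound 2 to compound 3 (0.60 log units; beyond the scatter) and is the only measured step beyond the scatter.

The next change puts 4-fluorophenyl in place of 2-chloro-6-fluorophenyl on a carbon with a double bond to nitrogen and keeps one six-membered aromatic ring of carbon only at that place.

All measured steps fall at this same place. The one beyond the scatter removes pyridin-3-yl, a group with no part in this change. The nearer guide is a 2.0-fold lower number from compound 1 to compound 3 (0.30 log units; within the scatter) as a swap between two carbon-only rings, while an at least 2.0-fold higher number from compound 1 to compound 2 (0.30 log units; that floor lies within the scatter) is only a floor.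

No step beyond the scatter is therefore expected in this assay and the estimate is a 1.6-fold higher number from compound 3 to compound 4 (0.20 log units; within the scatter) for this change. For compound 4 the estimated value is 40000 nM with an expected range from 15000 nM to 100000 nM on present evidence.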

Compound 4, half-maximal effective concentration: 100000 nM
Estimate against measurement, compound 4: 2.5-fold (0.40 log units) below; measured number inside the range.
By their numbers in this assay, from the lowest: compounds 3, 1 and 4 (each within the scatter of the next, the first and the last beyond it).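

In this assay the position on a carbon with a double bond to nitrogen shows a 4.0-fold higher number from compound 3 to compound 4 (0.60 log units; beyond the scatter) and so gives its first step beyond the scatter between two rings of carbon only; the earlier such step involved pyridin-3-yl. Fluoro in place of methylsulfanyl on an aromatic carbon gives a 2.0-fold higher number from compound 1 to compound 4 (0.30 log units; within the scatter) and leaves compound 1 and compound 4 without an order. Ring type alone therefore does not settle the number at this position, since compound 3 and compound 4 both carry one six-membered aromatic ring of carbon only and still stand apart beyond the scatter, while compound 1 lies within the scatter of each.

With 4-fluorophenyl in place of pyridin-3-yl the data give a number no higher from compound 2 to compound 4 (the limit leaves the size open) and the size of this step cannot be read. The value of compound 2 is a limit and not a number: the limit of > 100000 nM in this assay, at which 1 of the 4 values shown sits. The compounds shown do not separate the share of the chloro from that of the fluoro in 2-chloro-6-fluorophenyl, and they leave open what a phenyl ring carrying an amine or a carboxylic acid would give at this position.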